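A second fluorine on the phenyl ring of compound 3

The compounds below may be only part of what the source reports. "The series", "measured", "known", "first", "only" and "open" are said of these compounds alone.

Measured so far:
compound 1 `Cc1c(C(=O)Nc2ccc(Oc3ccnc4[nH]ccc34)c(F)c2)nnn1-c1ccc(F)c(F)c1` — 610 nM
compound 2 `Cc1c(C(=O)Nc2ccc(Oc3ccnc4[nH]ccc34)cc2)nnn1-c1ccccc1` — 350 nM
compound 3 `Cc1c(C(=O)Nc2ccc(Oc3ccnc4[nH]ccc34)cc2)nnn1-c1ccc(F)cc1` — 180 nM

In a functional assay on HT-29 cells (Homo sapiens) for cytotoxicity, read by MTT assay, with a stated time of 72 h (a lower number here means a stronger inhibitor, a higher number a weaker inhibitor), compound 3 gives the lowest number of the three. Its nearest neighbour is compound 2, and the step of a 1.9-fold lower number from compound 2 to compound 3 (0.29 log units; within the scatter) lies within the scatter. Among the compounds with values here, compound 1 gives a higher number than compound 3, but the two differ in two places, so no single step connects them. Compound 4 `Cc1c(C(=O)Nc2ccc(Oc3ccnc4[nH]ccc34)cc2)nnn1-c1ccc(F)c(F)c1` differs from compound 3 by fluoro in place of hydrogen on an aromatic carbon, read one bond further out as 4-fluorophenyl to 3,4-difluorophenyl. Within the data shown here, the only step that bears on this is the earlier fluoro-for-hydrogen change, a 1.9-fold lower number from compound 2 to compound 3 (0.29 log units; within the scatter), which stayed within the scatter. The step expected from this change is therefore a 1.4-fold higher number from compound 3 to compound 4 (0.14 log units; within the scatter). Compound 4 is estimated at 250 nM, between 100 nM and 650 nM.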

Compound 4, half-maximal inhibitory concentration: 1070 nM
For compound 4 the middle estimate is 4.3-fold (0.63 log units) below the measured one; measured number above the stated range.
By their numbers in this assay, from the lowest: compounds 3, 2, 1 and 4 (each within the scatter of the next, the first and the last beyond it).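

On this phenyl ring, fluoro in place of hydrogen ortho to a fluoro group is not a minor change: the step is a 5.9-fold higher number from compound 3 to compound 4 (0.77 log units; beyond the scatter), and the 3,4-difluorophenyl group also differs clearly from plain phenyl, a 3.1-fold higher number from compound 2 to compound 4 (0.49 log units; beyond the scatter). The fluoro that separates the other pair makes no clear difference, a 1.8-fold higher number from compound 1 to compound 4 (0.24 log units; within the scatter). The earlier fluoro-for-hydrogen steps stay small, so the size of this change depends on where it is made: the same change on two cores in this assay, a 1.9-fold lower number (0.29 log units; within the scatter) from compound 2 to compound 3 and a 1.8-fold lower number (0.24 log units; within the scatter) from compound 4 to compound 1, 1.1-fold (0.04 log units) apart, within the scatter of two such steps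

Still open, as far as these compounds go, is whether any group at this place would raise the number, or only fluoro. A chloro group, a methoxy group or an amine there would test this.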